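Swapping the Aryloxy Group for a Chloropiperidine

The source may report more compounds than this note shows. Statements on the series, on what has been measured and on what is new or still open speak of the compounds shown alone.

compound 1 `CC1=NN(C(=O)COc2ccc(Cl)cc2)C(c2ccccc2O)C1`: "not active" (no number reported)
compound 2 `CC1=NN(C(=O)COc2ccc(Cl)cc2)C(c2cc(Br)ccc2O)C1`: 23600 nM
compound 3 `CCC(=O)N1N=C(C)CC1c1cc(Br)cc(Br)c1O`: 38600 nM

All three compounds were tested in a functional assay on MGC-803 cells (Homo sapiens) for cytotoxicity, read by MTT assay, with a stated time of 48 h; a lower number here means a stronger inhibitor, a higher number a weaker inhibitor. Compound 1 stands at the bottom of this small set in one plain sense: it is reported as "not active" (no number reported), so it has no number that could be compared with the others. The two numbers that do exist, for compound 2 and compound 3, lie within the usual scatter of each other.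

The next compound to be measured is compound 4 `CC1=NN(C(=O)CN2CCC(Cl)CC2)C(c2ccccc2O)C1`. The change is 4-chloropiperidin-1-yl in place of 4-chlorophenoxy on a saturated chain carbon bound to a carbonyl carbon. The rest of the core of compound 1 stays as it is.

For the measured compounds named here, no measured pair shows what this exchange does, and a step cannot be counted from a compound without a number. The expectation is therefore modest: a small upward move in activity from compound 1, and no strong inhibitor. Compound 4 would then be expected to land in the region of compound 2 at 23600 nM. It may also, like compound 1, return no number at all. The estimated value for compound 4 is 40000 nM, with an expected range from 15000 nM to 100000 nM.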

Compound 4, half-maximal inhibitory concentration: 30300 nM
Beside the measured number, compound 4's estimate is 1.3-fold (0.12 log units) above it; the range from low to high includes it.
By their numbers in this assay, from the lowest: compounds 2, 4 and 3 (each within the scatter of the next).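

In this assay compound 1 stands as "not active" (no number reported) and compound 4 at 30300 nM so no step can be read between these two compounds. The compounds shown leave open what exchanging 4-chlorophenoxy for 4-chloropiperidin-1-yl does to activity. No supporting data bear on this result.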